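This account rests on a few compounds, and the source may have more. Where it says the series, first, only, none or still open, it means among the compounds named here.

Three related compounds have been measured in a physicochemical assay for lipophilicity; a higher number here means a more lipophilic compound, a lower number a more polar compound. Compound 1 `NC(=O)c1ccc[n+](CC[C@H](NC(=O)[C@@H]2CCC(=O)N2)C(=O)N2CCC[C@H]2C(N)=O)c1` gives -2.18 and compound 3 `CC(C)(C)OC(=O)N1C(=O)CCC1C(=O)NC(C[n+]1cccc(C(N)=O)c1)C(=O)N1CCCC1C(N)=O` gives -2.49. Compound 2 `NC(=O)c1ccc[n+](CCCC[C@H](NC(=O)[C@@H]2CCC(=O)N2)C(=O)N2CCC[C@H]2C(N)=O)c1` stands highest of the three at -1.29, and both of its gaps to the others lie beyond the scatter.

The next compound, compound 4 `NC(=O)C1=CN(CCC[C@H](NC(=O)[C@@H]2CCC(=O)N2)C(=O)N2CCC[C@H]2C(N)=O)C=CC1`, departs from compound 2 through one change: a group of 9 heavy atoms (6 carbon, 2 nitrogen, 1 oxygen; one six-membered non-aromatic ring with 1 hetero atom) in place of a group of 10 heavy atoms (7 carbon, 2 nitrogen, 1 oxygen; one six-membered aromatic ring with 1 hetero atom), on a saturated chain carbon, four bonds along the chain from an amide-type nitrogen and a carbonyl carbon. The group that leaves has a net charge of +1 and one six-membered aromatic ring with 1 hetero atom, while the group that enters has no net charge and a non-aromatic ring.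

Among the compounds with values here, only one measured step bears on this, and only in part. That step is a number 0.89 log units higher from compound 1 to compound 2 (beyond the scatter), and it came with a larger group of heavy atoms. Here the group becomes smaller, so that step alone points to a small fall. Within the data shown here, no measured step covers the loss of the net charge or of the aromatic ring, so the expectation of a rise rests on the structural change alone and remains uncertain.

The expected change is a number 0.79 log units higher from compound 2 to compound 4 (beyond the scatter), an estimated step of modest size. For compound 4 the estimated value is -0.5, with an expected range from -1.2 to 0.2.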

Compound 4, partition coefficient: -2.39
Compound 4: the middle estimate sits 1.89 log units above what was measured, and the stated range ends above it.
By their numbers in this assay, from the lowest: compounds 3, 4 and 1 (each within the scatter of the next, the first and the last beyond it); then compound 2.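

In this assay, the change at this saturated chain carbon gave a step of a number 1.10 log units lower from compound 2 to compound 4 (beyond the scatter) and so replaced the group with net charge +1 and a six-membered aromatic ring by one with no net charge and a six-membered non-aromatic ring without any rise in the number. Set against the other charged parent, the step of a number 0.21 log units lower from compound 1 to compound 4 (within the scatter) lies within the scatter, so compound 4 cannot be told apart from compound 1 in this read-out even though the two differ in both net charge and ring. Nothing measured here accounts for this result.

The compounds shown leave open which part of the change carries the large step from the higher compound, since the net charge, the ring and the size of the group all change together. As far as these compounds go, a benzene ring or a piperidine ring on the same chain carbon, or a longer chain bearing the same six-membered non-aromatic ring, would be needed to pull these parts apart, and how such groups would read remains unknown.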